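The source may hold more compounds than are shown below. What is called first, only, known or untested is meant among the compounds shown, and "the series" means these compounds.

The series is read in a functional assay on MDA-MB-468 cells (Homo sapiens) for cytotoxicity, read by sulforhodamine B assay, with a stated time of 48 h; on this read-out higher numbers stand for weaker inhibition of growth and lower numbers for stronger inhibition of growth. Compound 1 `CCN(CC)CN1C(=O)/C(=N\c2nc3ccc(C)cc3s2)c2ccccc21` gives 63500 nM there, and compound 2 `CCN(CC)CN1C(=O)/C(=N\c2nc3ccc(C)cc3s2)c2c(Br)cccc21`, which carries bromo in place of hydrogen on an aromatic carbon, gives 43100 nM. For the measured compounds named here, that pair makes up the single measured step: a 1.5-fold lower number from compound 1 to compound 2 (0.17 log units; within the scatter). Compound 3 `O=C1C(=O)N(CN(c2ccccc2)c2ccccc2)c2cccc(Cl)c21` gives 14400 nM, the lowest of the three numbers, and its gaps to compound 2 and to compound 1 both lie beyond the scatter.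

The step under consideration leads to compound 4 `O=C1C(=O)N(CN(c2ccccc2)c2ccccc2)c2ccccc21`, which differs from compound 3 in one place: hydrogen in place of chloro on an aromatic carbon. Going by the values given here, the only measured step that bears on it is a 1.5-fold lower number from compound 1 to compound 2 (0.17 log units; within the scatter), where a bromo group is added and the number stays within the scatter. The present change runs the other way, with a chloro leaving rather than a halide entering, and it sits on a different core at a different position, so the analogy is loose. On this basis the expected movement for compound 4 in this assay is small, with no direction beyond the scatter, and the step from compound 3 to compound 4 is estimated at a 1.4-fold higher number from compound 3 to compound 4 (0.14 log units; within the scatter). Compound 4 is therefore estimated at 20000 nM, with a range from 8000 nM to 50000 nM.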

Compound 4, concentration for 50% growth inhibition: 21500 nM
Estimate against measurement, compound 4: 1.1-fold (0.03 log units) below; the range from low to high includes it.
By their numbers in this assay, from the lowest: compounds 3, 4, 2 and 1 (each within the scatter of the next, the first and the last beyond it).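

In this assay, taking the chloro off the aromatic carbon that is ortho to a fused ring and meta to a fused ring gives a 1.5-fold higher number from compound 3 to compound 4 (0.17 log units; within the scatter), so on the core of compound 3 the chloro is not needed for a number in this range. For the compounds shown here, this is the first reading of a chloro at this place, and it sets a second halogen step beside the bromo step on the core of compound 1, a 1.5-fold lower number from compound 1 to compound 2 (0.17 log units; within the scatter), with both steps lying within the scatter on their separate cores. Nothing available gives a reason for the small size of either step.

The compounds shown leave open whether a group of another kind on this aromatic carbon, such as an amine, a carboxylic acid or a methoxy group, would move the number beyond the scatter, as neither halogen step does. They also leave open which structural part separates the compounds built on the core of compound 3 from those built on the core of compound 1, as these differ in more than one place.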